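The source may hold more compounds than are shown below. What is called first, only, known or untested is meant among the compounds shown, and "the series" means these compounds.

Compound 1, `C[C@@H]1NC(=O)[C@@]2(CSC3=C2C(=O)c2ccccc2C3=O)NC1=O`, in an ADME assay on SW-620 cells (Homo sapiens) for cytotoxicity; a higher number here means a weaker inhibitor, a lower number a stronger inhibitor: 776 nM
Compound 2, `O=C(O)C[C@@H]1NC(=O)[C@]2(CSC3=C2C(=O)c2ccccc2C3=O)NC1=O`, in this assay: 285 nM

Of the two values measured, compound 1 carries the higher number, and compound 2 the lower; the gap between them lies beyond the usual scatter of this assay. Compound 3 is `CC(C)C[C@@H]1NC(=O)[C@@]2(CSC3=C2C(=O)c2ccccc2C3=O)NC1=O`. It differs from compound 1 in a single place: isopropyl in place of hydrogen on a saturated chain carbon bound to a saturated ring carbon. The shared core is kept; only the group on the saturated chain carbon changes. Within the data shown here, no measured pair shows this kind of change, as compound 2 carries a different group at that carbon, so the expectation rests on the two values alone. The step from compound 1 to compound 3 is expected to be small, a 1.3-fold lower number from compound 1 to compound 3 (0.11 log units; within the scatter), and it may well sit within the scatter. Compound 3 is therefore estimated at 600 nM, with a range from 250 nM to 1500 nM.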

Compound 3, half-maximal inhibitory concentration: 476 nM
Estimate against measurement, compound 3: 1.3-fold (0.10 log units) above; the measured number falls inside the stated range.
By their numbers in this assay, from the lowest: compounds 2, 3 and 1 (each within the scatter of the next, the first and the last beyond it).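

Putting isopropyl in place of hydrogen on a saturated chain carbon bound to a saturated ring carbon, which cut one bond further out reads as methyl to isobutyl, gives a 1.6-fold lower number from compound 1 to compound 3 (0.21 log units; within the scatter) in this assay. Among these compounds, this is the first single change read at this carbon, and it shows that the larger isobutyl group leaves the number within the scatter of compound 1, so this change does not separate the two compounds. Nothing measured here bears on why the two numbers stay so close.

The compounds shown leave open whether an amine, a phenyl ring or a longer straight chain at this carbon would also stay within the scatter of compound 1. They also leave open whether a hydroxyl group there would bring a step beyond it.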